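This account rests on a few compounds, and the source may have more. Where it says the series, first, only, none or still open, it means among the compounds named here.

In an in vitro ADME assay on microsomes from liver (Homo sapiens) for pharmacokinetics, read by LC-MS, with a stated time of 10 min, tested at 1 uM (a lower number here means slower removal, a higher number faster removal of the compound), compound 1 `COc1ccc(NC(=O)[C@H]2CN(C)C[C@@H]2c2ccc(/C=C/C(=O)Nc3ccccc3N)cc2)cc1` gives 14 mL/min/kg and compound 2 `CN1C[C@H](C(=O)Nc2ccc(C3CC3)cc2)[C@@H](c2ccc(/C=C/C(=O)Nc3ccccc3N)cc2)C1` gives 12 mL/min/kg while compound 3 `CN1C[C@H](C(=O)Nc2ccc(F)c(Cl)c2)[C@@H](c2ccc(/C=C/C(=O)Nc3ccccc3N)cc2)C1` gives 15 mL/min/kg on the same scale. Compound 3 thus stands level with the other two. Compound 4 `CN1C[C@H](C(=O)Nc2ccc(F)c(Br)c2)[C@@H](c2ccc(/C=C/C(=O)Nc3ccccc3N)cc2)C1` differs from compound 3 in one place (bromo in place of chloro on an aromatic carbon) with bromo in place of chloro on an aromatic carbon, ortho to a fluoro group. Among the measured compounds shown here, no measured step makes this exact swap. The closest evidence is the exchange of the whole group on the amide-type nitrogen, where a 1.1-fold higher number from compound 1 to compound 3 (0.03 log units; within the scatter) and a 1.3-fold higher number from compound 2 to compound 3 (0.10 log units; within the scatter) stayed within the scatter, as did a 1.2-fold lower number from compound 1 to compound 2 (0.07 log units; within the scatter) for cyclopropyl in place of methoxy. The expected change in this assay is no change at the digits printed from compound 3 to compound 4 (within the scatter) and so stays within the scatter. Compound 4 is estimated at 15 mL/min/kg with an expected range from 9 mL/min/kg to 24 mL/min/kg as its likely span.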

Compound 4, clearance: 15 mL/min/kg
Compound 4: middle estimate and measured number agree at the digits printed; the range from low to high includes it.
By their numbers in this assay, from the lowest: compounds 2, 1, 3 and 4 (each within the scatter of the next).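

In this assay, the direct swap of bromo for chloro, ortho to a fluoro group, gives no change at the digits printed from compound 3 to compound 4 (within the scatter), so at this place the two halogens cannot be told apart by this read-out. The 3-bromo-4-fluorophenyl group also compares with the other groups on the amide-type nitrogen, with a 1.3-fold higher number from compound 2 to compound 4 (0.10 log units; within the scatter) and a 1.1-fold higher number from compound 1 to compound 4 (0.03 log units; within the scatter), so all four compounds lie within the scatter of one another. No measurement available here gives a reason for this flat result. The compounds shown leave open whether an amine or a carboxylic acid at this same place would keep the clearance in this range.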